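Putting a benzoyl group on compound 2

This account rests on a few compounds, and the source may have more. Where it says the series, first, only, none or still open, it means among the compounds named here.

In a functional assay on Hs 683 cells (Homo sapiens) for inhibition, read by MTT assay, with a stated time of 72 h (on this read-out higher numbers stand for weaker inhibition of growth and lower numbers for stronger inhibition of growth), compound 2 (`CC(C)[Si]1(C(C)C)OC[C@H]2O[C@@H](n3ccc(=O)[nH]c3=O)[C@H](O)[C@@H]2O[Si](C(C)C)(C(C)C)O1`) gives 83000 nM and lies within the scatter of its two relatives. Compound 1 (`Cc1cn([C@@H]2O[C@H](CO[Si](C)(C)C(C)(C)C(C)C)[C@@H](O)[C@H]2O)c(=O)[nH]c1=O`) gives 64000 nM on the same scale and compound 3 (`Cc1cn([C@@H]2O[C@@H]3CO[Si](C(C)C)(C(C)C)O[Si](C(C)C)(C(C)C)O[C@H]3[C@H]2O)c(=O)[nH]c1=O`) gives 91000 nM on it too. Compound 4 (`CC(C)[Si]1(C(C)C)OC[C@H]2O[C@@H](n3ccc(=O)n(C(=O)c4ccccc4)c3=O)[C@H](O)[C@@H]2O[Si](C(C)C)(C(C)C)O1`) differs from compound 2 by one change, benzoyl in place of hydrogen on an aromatic nitrogen. Among the measured compounds shown here, the one measured step (a 1.1-fold higher number from compound 2 to compound 3 (0.04 log units; within the scatter)) put methyl in place of hydrogen on an aromatic carbon, a much smaller group, so it guides only loosely. No step beyond the scatter is therefore expected in this assay, and the estimated change is small (a 1.4-fold lower number from compound 2 to compound 4 (0.14 log units; within the scatter)). Compound 4 is estimated at 60000 nM (expected range 20000 nM to 120000 nM).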

Compound 4, concentration for 50% growth inhibition: 29000 nM
Estimate against measurement, compound 4: 2.1-fold (0.32 log units) above, within the range that was stated.
By their numbers in this assay, from the lowest: compound 4; then compounds 1, 2 and 3 (each within the scatter of the next).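

In this assay, benzoyl in place of hydrogen on the aromatic nitrogen gives a 2.9-fold lower number from compound 2 to compound 4 (0.46 log units; beyond the scatter), so this position responds to a change, if only modestly, and the lower number stands for stronger inhibition of growth. The earlier methyl step on an aromatic carbon, a 1.1-fold higher number from compound 2 to compound 3 (0.04 log units; within the scatter), showed no such shift. Nothing at hand accounts for this shift.

Only one group on this nitrogen is shown, so whether acetyl or methyl there, or an amine on the benzoyl ring, would move the number stays open. From the compounds shown here alone, whether benzoyl on compound 3 gives a similar step also stays open.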